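Benzyloxy extension on the aniline of compound 2

The source may report more compounds than this note shows. Statements on the series, on what has been measured and on what is new or still open speak of the compounds shown alone.

Of the compounds shown here, two have been measured in a functional assay on NCI-H1975 cells (Homo sapiens) for antiproliferative activity, read by MTT assay, with a stated time of 72 h; a lower number here means a stronger inhibitor, a higher number a weaker inhibitor. Compound 2 `COc1cc2ncnc(Nc3cccc(Cl)c3)c2cc1OCCCCC(=O)Nc1ccc(S(N)(=O)=O)cc1` gives 33200 nM, which is the smaller of the two numbers. Its nearest neighbour, compound 1 `COc1cc2ncnc(Nc3ccc(F)c(Cl)c3)c2cc1OCCCCC(=O)Nc1ccc(S(N)(=O)=O)cc1`, gives 35600 nM in this assay, and the step of a 1.1-fold lower number from compound 1 to compound 2 (0.03 log units; within the scatter) is within the scatter, so the two cannot be ordered. Compound 3 `COc1cc2ncnc(Nc3ccc(OCc4cccc(F)c4)c(Cl)c3)c2cc1OCCCCC(=O)Nc1ccc(S(N)(=O)=O)cc1` differs from compound 2 by (3-fluorobenzyl)oxy in place of hydrogen on an aromatic carbon. Among the compounds with values here, the single measured step, from compound 1 to compound 2, concerns a different position and the loss of a single fluorine, and it stayed within the scatter; no measured step bears on the entry of a (3-fluorobenzyl)oxy group of this size. The expectation therefore rests on compound 2 alone and carries a wide range. For compound 3 the estimated step of a 1.7-fold lower number from compound 2 to compound 3 (0.22 log units; within the scatter) is a modest lowering of the number, not clearly beyond the scatter. Compound 3 is expected to give 20000 nM in this assay, within 4000 nM to 80000 nM.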

Compound 3, half-maximal inhibitory concentration: 5670 nM
Beside the measured number, compound 3's estimate is 3.5-fold (0.55 log units) above it; low and high end bracket the measured number.
By their numbers in this assay, from the lowest: compound 3; then compounds 2 and 1 (each within the scatter of the next).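

In this assay the aromatic carbon ortho to a chloro group proves responsive to substitution: fluoro and hydrogen there could not be told apart, yet (3-fluorobenzyl)oxy in place of hydrogen gives a 5.9-fold lower number from compound 2 to compound 3 (0.77 log units; beyond the scatter) as the step. The same holds against fluoro at that carbon, with a 6.3-fold lower number from compound 1 to compound 3 (0.80 log units; beyond the scatter) as the step, so the lower number for compound 3 does not depend on which small occupant it is set against. No data on hand account for either step.

As far as these compounds go, it remains open whether the whole (3-fluorobenzyl)oxy group is needed, or whether a methoxy group or an unsubstituted benzyloxy group would give a similar step. Also open, from the compounds shown here alone, is how a carboxylic acid in place of the sulfonamide would behave alongside the (3-fluorobenzyl)oxy group.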